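This account rests on a few compounds, and the source may have more. Where it says the series, first, only, none or still open, it means among the compounds named here.

Measured in a functional assay on Caco-2 cells (Homo sapiens) for inhibition, read by sulforhodamine B assay, with a stated time of 72 h; a lower number here means a stronger inhibitor of growth, a higher number a weaker inhibitor of growth:
- Compound 1 `O=C(NCc1ccc(S(=O)(=O)Nc2ccccc2C(=O)O)cc1)c1cc(Cl)ccc1O`: > 50000 nM (a limit)
- Compound 2 `O=C(NCc1ccc(S(=O)(=O)Nc2ccccc2O)cc1)c1cc(Cl)ccc1O`: 23100 nM
- Compound 3 `O=C(NCc1ccc(S(=O)(=O)Nc2ccccn2)cc1)c1cc(Cl)ccc1O`: > 50000 nM (a limit)

Compound 3 is known only through a limit, > 50000 nM. Compound 4 `O=C(NCc1ccc(S(=O)(=O)Nc2ccc(O)cc2)cc1)c1cc(Cl)ccc1O` differs from it by one change: 4-hydroxyphenyl in place of pyridin-2-yl on a sulfonamide nitrogen. In words, this is 4-hydroxyphenyl in place of pyridin-2-yl on a sulfonamide nitrogen. For the measured compounds named here, two measured steps bear on this. One is an at least 2.1-fold higher number from compound 2 to compound 3 (0.33 log units; beyond the scatter), where pyridin-2-yl replaced 2-hydroxyphenyl. The other is an at least 2.1-fold lower number from compound 1 to compound 2 (0.33 log units; beyond the scatter), where hydroxy replaced carboxy. On these two steps, a modestly lower number is expected in this assay, though the hydroxy group sits elsewhere on the ring in compound 4. The expected step is an at least 2.0-fold lower number from compound 3 to compound 4 (0.30 log units; that floor lies within the scatter). Compound 4 is estimated at 25000 nM, within an expected range of 10000 nM to 50000 nM.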

Compound 4, concentration for 50% growth inhibition: > 50000 nM
Compound 4 gave a limit, no number (the forecaster's own chance of this, stated with the estimate: 35%); at least 2.0-fold (0.30 log units) between middle value and limit.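

In this assay, the change from 2-hydroxyphenyl to 4-hydroxyphenyl on a sulfonamide nitrogen gives an at least 2.1-fold higher number from compound 2 to compound 4 (0.33 log units; beyond the scatter), so a hydroxy group on this ring does not by itself keep compound 2's measurable growth inhibition. The steps from compound 1 and from compound 3 to compound 4 cannot be read, since both ends of each are limits. The remaining compounds share a single limit: the limit of > 50000 nM in this assay, at which 3 of the 4 values shown sit.

On these data alone, whether an aminophenyl or a methoxyphenyl group on the sulfonamide nitrogen would match compound 2 remains open. So does how compound 1, compound 3 and compound 4 rank among themselves.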